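The source may report more compounds than this note shows. Statements on the series, on what has been measured and on what is new or still open speak of the compounds shown alone.

Of the compounds shown here, two of a shared core have been measured in an ADME assay for permeability, using PAMPA, with a stated time of 30 min, at pH 7.4; on this read-out lower numbers stand for lower permeability and higher numbers for higher permeability. Compound 1, `COc1cccc(CNCCCNc2ccnc3cc(Oc4ccccc4)ccc23)c1O`, carries a phenoxy group and in this assay gives 317 10^-6 cm/s. Compound 2, `COc1cccc(CNCCCNc2ccnc3cc(-c4ccc(F)cc4)ccc23)c1O`, carries a 4-fluorophenyl group in the same place and in this assay gives 237 10^-6 cm/s. Within the data shown here, the single measured step, a 1.3-fold lower number from compound 1 to compound 2 (0.13 log units; within the scatter), shows that these two numbers lie within the scatter of each other, so no order between compound 1 and compound 2 can be read from them.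

Compound 3, `COc1cccc(CNCCCNc2ccnc3cc(Oc4ccc(C(C)(C)C)cc4)ccc23)c1O`, is the next compound. Relative to compound 2 it changes as follows: 4-(tert-butyl)phenoxy in place of 4-fluorophenyl on an aromatic carbon. Among the measured compounds shown here, the only measured step bears on this change in part, since it too exchanges the group at this aromatic carbon, and it stayed within the scatter. For the measured compounds named here, no measured step covers the tert-butyl part of the new group. On that basis, compound 3 is expected to stay close to compound 2, with a step of a 1.1-fold higher number from compound 2 to compound 3 (0.06 log units; within the scatter), within the scatter. The estimate for compound 3 in this assay is 270 10^-6 cm/s, with a range from 150 10^-6 cm/s to 450 10^-6 cm/s.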

Compound 3, apparent permeability: 317 10^-6 cm/s
Compound 3: middle estimate off by 1.2-fold (0.07 log units), on the low side, within the range that was stated.
By their numbers in this assay, from the lowest: compounds 2, 1 and 3 (each within the scatter of the next).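

Among these compounds, compound 3 gives the first reading on the tert-butyl part of the new group: with tert-butyl in place of hydrogen on an aromatic carbon, no change at the digits printed from compound 1 to compound 3 (within the scatter) in this assay, so adding this group to the phenoxy of compound 1 moves the number by nothing that can be told from the usual scatter. The larger exchange at the same position, 4-(tert-butyl)phenoxy with 11 heavy atoms in place of 4-fluorophenyl with 7, gives a 1.3-fold higher number from compound 2 to compound 3 (0.13 log units; within the scatter), which also stays within the scatter, so all three compounds now lie too close for any order among them to be read. Nothing measured here gives a reason for this closeness.

All three groups at this aromatic carbon carry a six-membered aromatic ring of carbon, so the compounds shown leave open whether a group without such a ring, such as an amine or a carboxylic acid, would give a step beyond the scatter. Among the compounds shown here, they also leave open how the number responds to a change anywhere else on the shared core or its side chain, since every step so far falls at this one position.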